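The source may hold more compounds than are shown below. What is called first, only, known or untested is meant among the compounds shown, and "the series" means these compounds.

Measured compounds:
compound 1 `O=C1CCCC2=C1C(c1ccccc1Cl)N=C(c1cnccn1)N2`, 1470000 nM
compound 2 `O=C1CCCC2=C1C(c1ccccc1Cl)N=C(c1cccnc1)N2`, 1120000 nM
compound 3 `CC1(C)CC(=O)C2=C(C1)NC(c1cnccn1)=NC2c1ccc(F)cc1Cl`, 773000 nM

All three values come from an ADME assay on HepG2 2.2.15 cells (Homo sapiens) for cytotoxicity; on this read-out higher numbers stand for weaker inhibition and lower numbers for stronger inhibition. Compound 2 differs from compound 1 by pyridin-3-yl in place of pyrazin-2-yl on a carbon with a double bond to nitrogen; that step gave a 1.3-fold lower number from compound 1 to compound 2 (0.12 log units; within the scatter). Compound 4 `CC1(C)CC(=O)C2=C(C1)NC(c1cccnc1)=NC2c1ccc(F)cc1Cl` is not yet measured; it differs from compound 3 by pyridin-3-yl in place of pyrazin-2-yl on a carbon with a double bond to nitrogen. The difference between the cores of compound 1 and compound 3 is not broken down here. The change from compound 3 to compound 4 is the same kind of change as that from compound 1 to compound 2, though the ring atom two ring bonds away bears a 2-chloro-4-fluorophenyl group rather than a 2-chlorophenyl group. A step of about the earlier size is expected, a 1.2-fold lower number from compound 3 to compound 4 (0.10 log units; within the scatter), because a 1.3-fold lower number from compound 1 to compound 2 (0.12 log units; within the scatter). In this assay compound 4 is estimated at 620000 nM, expected between 350000 nM and 1200000 nM.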

Compound 4, half-maximal inhibitory concentration: 624000 nM
Compound 4: the middle estimate sits 1.0-fold (0.00 log units) below what was measured, within the range that was stated.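

In this assay, pyridin-3-yl in place of pyrazin-2-yl gives a 1.2-fold lower number from compound 3 to compound 4 (0.09 log units; within the scatter). The step on this second core agrees with the earlier one: the same change on two cores in this assay, a 1.3-fold lower number (0.12 log units; within the scatter) from compound 1 to compound 2 and a 1.2-fold lower number (0.09 log units; within the scatter) from compound 3 to compound 4, 1.1-fold (0.03 log units) apart, within the scatter of two such steps. The change therefore carries across these two cores without a discernible difference, but each step lies within the scatter, so no effect of the change is shown on either core, and nothing follows for other cores.

Still open, going by these compounds, is whether any other group on this carbon, such as an amine or a carboxylic acid in place of the aromatic ring, would give a step beyond the scatter. The separate contributions of the differences between the core of compound 1 and the core of compound 3 also remain unresolved.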